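A few compounds are considered here, and "the series" means these few. Any claim that something is new, unique, unknown or untested is made for them only; others in the source may bear on it.

Of the compounds shown here, three have been tested for how strongly they harm a rat muscle cell line. Compound 1 `CC1(C)CCc2c(ccc(CNCCCc3ccccc3)c2O)O1` and compound 2 `CC1(C)CCc2c(ccc(CNCCCCc3ccccc3)c2O)O1` share one core, while compound 3 `CC1(C)C=Cc2cc(CNCCCc3ccccc3)c(O)cc2O1` and the untested compound 4 `CC1(C)C=Cc2cc(CNCCCCc3ccccc3)c(O)cc2O1` share another; how the two cores differ is not broken down here. In a toxicity assay on L6 cells (Rattus norvegicus) for inhibition, read by microscopy and resazurin assay, with a stated time of 70 h (on this read-out lower numbers stand for stronger inhibition and higher numbers for weaker inhibition), compound 1 gives 27000 nM. In this assay compound 2 gives 15000 nM. In this assay compound 3 gives 28000 nM. All three numbers lie close to one another, within the ordinary spread of such measurements.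

Compound 2 differs from compound 1 by one change: benzyl in place of phenyl on a saturated chain carbon, three bonds along the chain from an amine nitrogen That change produced a 1.8-fold lower number from compound 1 to compound 2 (0.26 log units; within the scatter). Exactly the same change leads from compound 3 to compound 4: benzyl in place of phenyl on a saturated chain carbon, three bonds along the chain from an amine nitrogen Since the place of the change reads the same in both pairs, and the first instance moved the number only a little, the expectation is that compound 4 will sit close to compound 3, with an estimated step of a 1.6-fold lower number from compound 3 to compound 4 (0.22 log units; within the scatter), resting on the size of the step from compound 1 to compound 2. For compound 4 the estimated value in this assay is 17000 nM, expected to fall between 8000 nM and 36000 nM.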

Compound 4, half-maximal inhibitory concentration: 19000 nM
Compound 4: the middle estimate sits 1.1-fold (0.05 log units) below what was measured; the measured number falls inside the stated range.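

In this assay, benzyl in place of phenyl gives a 1.5-fold lower number from compound 3 to compound 4 (0.17 log units; within the scatter), and this step agrees with the one seen earlier on the other core: the same change on two cores in this assay, a 1.8-fold lower number (0.26 log units; within the scatter) from compound 1 to compound 2 and a 1.5-fold lower number (0.17 log units; within the scatter) from compound 3 to compound 4, 1.2-fold (0.09 log units) apart, within the scatter of two such steps. The change therefore carries over from one core to the other in the only sense these data allow: on both cores the step stays small, and the two steps cannot be told apart. It does not show that the change itself truly shifts the number, since each step lies within the scatter, and two pairs in a single cell assay say nothing about other cores or other kinds of test.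

Still open, as far as these compounds go, is whether a larger change at this place, such as a longer chain, or a fluorine or a carboxylic acid on the benzyl ring, would move the number beyond the scatter. Also open, from the compounds shown here alone, is whether such a larger step would again come out alike on both cores.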